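From 3-methylpiperidin-1-yl to 4-methylpiperidin-1-yl: a step among limits

A few compounds are considered here, and "the series" means these few. Any claim that something is new, unique, unknown or untested is made for them only; others in the source may bear on it.

Three related compounds have been measured so far. In an ADME assay on MT4 cells (Homo sapiens) for cytotoxicity, read by MTT assay, with a stated time of 4 days (a lower number here means that less compound is tolerated, a higher number that more compound is tolerated), compound 1 (`CC1CCN(c2nc(Cc3c(F)cccc3F)cc(=O)[nH]2)CC1`) gives > 78000 nM as a limit of the assay. In this assay compound 2 (`CCCN(C)c1nc(Cc2c(F)cccc2F)c(C)c(=O)[nH]1`) gives > 81000 nM which is also a limit. Compound 3 (`Cc1c(Cc2c(F)cccc2F)nc(N2CCCC(C)C2)[nH]c1=O`) gives > 75000 nM as a limit too, so it stands without a number of its own.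

Compound 4 (`Cc1c(Cc2c(F)cccc2F)nc(N2CCC(C)CC2)[nH]c1=O`) has the same atoms as compound 3, joined differently, and the change is 4-methylpiperidin-1-yl in place of 3-methylpiperidin-1-yl on an aromatic carbon at the aromatic carbon between two ring nitrogen atoms. Among the measured compounds shown here, only one measured step bears on this place, namely a step that the two limits leave unreadable from compound 2 to compound 3 and it offers no size to carry over. The entering 4-methylpiperidin-1-yl also occurs in compound 1, whose > 78000 nM is again only a limit. With all three values at a limit, no direction can be given in this assay and no change beyond the scatter is expected. The expected step that the limit leaves unreadable from compound 3 to compound 4 is estimated to stay within the usual scatter. For compound 4 the estimate is 80000 nM with an expected range from 40000 nM to 110000 nM and the assay will probably report only a limit again.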

Compound 4, half-maximal cytotoxic concentration: > 75000 nM
Compound 4 was reported as a limit (the forecaster's own chance of this, stated with the estimate: 85%); the middle value lies beyond the limit too.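

In this assay compound 4 gives > 75000 nM, again a limit. All four values are limits, and the steps to compound 4 from compound 1, compound 2 and compound 3 cannot be read. The compounds shown leave open whether any of these changes, including 4-methylpiperidin-1-yl in place of 3-methylpiperidin-1-yl, alters the concentration tolerated in this assay.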